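The source may hold more compounds than are shown below. What is called first, only, known or untested is meant among the compounds shown, and "the series" means these compounds.

Compound 3 `CCNc1cc(-c2ccc(NC(=O)Nc3c(C)cccc3C)cc2C(F)(F)F)ccn1` gives 59.2% in an assay on isolated protein for inhibition of serine/threonine-protein kinase PLK1 (Homo sapiens), read by radiometric assay and 33P incorporation, with a stated time of 40 min, tested at 20 uM, in the presence of a further agent that is not named here (on this read-out higher numbers stand for more inhibition at the one concentration tested (going by the name of the read-out) and lower numbers for less inhibition), the lowest of the three numbers, though compound 1 `CCNc1cc(-c2ccc(NC(=O)Nc3ccc(OC)cc3)cc2C(F)(F)F)ccn1` with 62.1% sits within the scatter of it, while compound 2 `CCNc1cc(-c2ccc(NC(=O)Nc3ccc(C(F)(F)F)cc3)cc2C(F)(F)F)ccn1` with 82.9% stands clearly higher. Compound 4 `CCNc1cc(-c2ccc(NC(=O)Nc3ccccc3Cl)cc2C(F)(F)F)ccn1` differs from compound 3 by 2-chlorophenyl in place of 2,6-dimethylphenyl on an amide-type nitrogen. Two measured steps exchange the same aryl group on the amide-type nitrogen: a number 2.9 percentage points lower from compound 1 to compound 3 (within the scatter) and a number 23.7 percentage points lower from compound 2 to compound 3 (beyond the scatter). Such exchanges have therefore moved this assay by anything from nothing to a modest amount. For the measured compounds named here, no measured compound carries 2-chlorophenyl, so the direction is open, and a shift of at most modest size is expected, a number 5.8 percentage points higher from compound 3 to compound 4 (within the scatter). For compound 4 the estimated value is 65%, with a range from 45% to 85%.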

Compound 4, a percentage reported as inhibition, at one concentration (the size of the read-out at that concentration, not a potency): 71.6%
Estimate against measurement, compound 4: 6.6 percentage points below, and the stated range covers the measured number.
By their numbers in this assay, from the lowest: compounds 3, 1 and 4 (each within the scatter of the next, the first and the last beyond it); then compound 2.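

With 2-chlorophenyl on the amide-type nitrogen, the number falls clear of both earlier ends of the series, with a number 12.4 percentage points higher from compound 3 to compound 4 (beyond the scatter) and a number 11.3 percentage points lower from compound 2 to compound 4 (beyond the scatter) as the two steps. Against 4-methoxyphenyl the exchange gives a number 9.5 percentage points higher from compound 1 to compound 4 (within the scatter) and so does not separate the two groups. Exchanges at this nitrogen therefore give graded numbers rather than two distinct levels. Still open, on these data alone, is whether a nitrile, an amine or a carboxylic acid in place of the chlorine would hold, raise or lower the number. Nothing available here accounts for these shifts.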